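Moving one hydroxyl arm on the shared quaternary carbon

The compounds below may be only part of what the source reports. "The series", "measured", "known", "first", "only" and "open" are said of these compounds alone.

Three compounds share one core with two short arms on the same amine-bearing carbon. Compound 1 `CCCCCCCCc1ccc(CCC(N)(CO)C(=O)O)cc1` carries a carboxy arm; in a functional assay on the whole organism (spleen, spleen) with Rattus norvegicus as the target (on this read-out higher numbers stand for an effect only at larger amounts of compound and lower numbers for an effect already at smaller amounts), compound 1 gives only a limit, > 10 mg/kg, rather than a number (the limit of > 10 mg/kg in this assay, at which 1 of the 3 values shown sits). Compound 2 `CCCCCCCCc1ccc(CCC(N)(CO)CCO)cc1` carries a 2-hydroxyethyl arm and in this assay gives 0.009 mg/kg. Compound 3 `CCCCCCCCc1ccc(CCC(N)(CO)CCCO)cc1` carries a 3-hydroxypropyl arm and gives 0.085 mg/kg; among the two numbers shown, compound 3 stands highest, the step being a 9.4-fold higher number from compound 2 to compound 3 (0.98 log units; beyond the scatter).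

Compound 4 `CCCCCCCCc1ccc(CCC(N)(CCO)CCO)cc1` rearranges the same atoms: a group of 8 heavy atoms (5 carbon, 1 nitrogen, 2 oxygen; no ring) in place of a group of 8 heavy atoms (5 carbon, 1 nitrogen, 2 oxygen; no ring), on a saturated chain carbon, two bonds along the chain from an aromatic carbon. The measured steps do not match this change directly. The nearest guide is the step from hydroxy to hydroxymethyl that gave a 9.4-fold higher number from compound 2 to compound 3 (0.98 log units; beyond the scatter), a modest rise; compound 4 shortens that arm again while lengthening the other, so the two effects may partly cancel. A step of about a 1.2-fold higher number from compound 3 to compound 4 (0.07 log units; within the scatter) is therefore expected. Compound 4 is estimated at 0.1 mg/kg, with a plausible range from 0.015 mg/kg to 0.7 mg/kg.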

Compound 4, dose for 50% inhibition: > 10 mg/kg
Compound 4 was reported as a limit; the forecaster's own chance of this, stated with the estimate: 5%; middle value at least 100-fold (2.00 log units) away from the limit.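

Lengthening the hydroxymethyl arm is a far harsher change than lengthening the other arm: it gives an at least 1100-fold higher number from compound 2 to compound 4 (3.04 log units; beyond the scatter) in this assay. Redistributing the same atoms between the two arms is just as costly, with an at least 110-fold higher number from compound 3 to compound 4 (2.07 log units; beyond the scatter), so the two arms cannot be treated as interchangeable even though the atom counts match. Compound 4 gives only a limit, as compound 1 does, so the step between these two cannot be read: the limit of > 10 mg/kg in this assay, at which 2 of the 4 values shown sit.

From the compounds shown here alone, what an amine or a methyl group would do in place of the hydroxyl on the hydroxymethyl arm stays open. The compounds shown also give no reason for the loss.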